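The compounds below may be only part of what the source reports. "The series", "measured", "known", "first", "only" and "open" are said of these compounds alone.

Compound 1 `C=CCc1cc(C(C)=O)c(O)cc1OCCCCCCC#N` in an assay on isolated protein for binding affinity to leukotriene B4 receptor 1 (Homo sapiens), tested at 1 uM; on this read-out higher numbers stand for more inhibition at the one concentration tested (going by the name of the read-out) and lower numbers for less inhibition: compound 1 gives 63%. Compound 2 `C=CCc1cc(C(C)=O)c(O)cc1OCCCCCCCC#N`: compound 2 gives 52%. Compound 3 `C=CCc1cc(C(C)=O)c(O)cc1OCCCCCCCCCCC#N`: compound 3 gives 14%.

Among these three, compound 3 stands lowest in this assay, with a number 38 percentage points lower from compound 2 to compound 3 (beyond the scatter) and a number 49 percentage points lower from compound 1 to compound 3 (beyond the scatter). Compound 4 `C=CCc1cc(C(C)=O)c(O)cc1OCCCC` differs from compound 3 in one place: hydrogen in place of 6-cyanohexyl on a saturated chain carbon, four bonds along the chain from an oxygen on an aromatic ring. Every measured step runs the other way, lengthening the chain that carries the nitrile: a number 11 percentage points lower from compound 1 to compound 2 (beyond the scatter), then a number 49 percentage points lower from compound 1 to compound 3 (beyond the scatter) and a number 38 percentage points lower from compound 2 to compound 3 (beyond the scatter), each a drop in inhibition. Among the measured compounds shown here, the step to compound 4 shortens the chain and removes the nitrile, a change none of the measured compounds covers, so a rise is expected but its size is uncertain. Compound 4 is estimated at 40%, within 10% to 75%. This expected step, a number 26 percentage points higher from compound 3 to compound 4 (beyond the scatter), is the author's estimate only.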

Compound 4, a percentage reported as inhibition, at one concentration (the size of the read-out at that concentration, not a potency): 8%
Compound 4: middle estimate off by 32 percentage points, on the high side; the whole stated range lies above it.
By their numbers in this assay, from the lowest: compounds 4 and 3 (each within the scatter of the next); then compound 2; then compound 1.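

In this assay, hydrogen in place of 6-cyanohexyl at this saturated chain carbon gives a number 6 percentage points lower from compound 3 to compound 4 (within the scatter), so the long nitrile chain and the plain butyl-length chain cannot be told apart. The same kind of change from the shorter nitrile chains gives a number 44 percentage points lower from compound 2 to compound 4 (beyond the scatter) and a number 55 percentage points lower from compound 1 to compound 4 (beyond the scatter), so compound 4 goes against the earlier pattern, in which shorter chains gave higher numbers. Nothing at hand bears on why this is so. Still open, as far as these compounds go, is whether the nitrile or the chain length carries the inhibition. A carboxylic acid or an amine in place of the nitrile of compound 1 would bear on that, as would a shorter chain ending in a nitrile.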